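A few compounds are considered here, and "the series" means these few. Any claim that something is new, unique, unknown or untested is made for them only; others in the source may bear on it.

Of the compounds shown here, three have been measured in a functional assay on isolated protein for agonist activity at Glucose-dependent insulinotropic receptor (Rattus norvegicus), read by HTRF and cAMP accumulation; a higher number here means that more compound is needed for the effect, a lower number that less compound is needed. Compound 1 `CC(C)(C)OC(=O)N1CCC(O[C@H]2CC[C@@H](Oc3ccc(S(C)(=O)=O)cc3)CC2)CC1` gives 1390 nM, compound 2 `CC(C)(C)OC(=O)N1CCC(O[C@H]2CC[C@H](Oc3ccc(S(C)(=O)=O)cc3F)CC2)CC1` gives 61 nM, and compound 3 `C[C@@H](CF)OC(=O)N1CCC(O[C@H]2CC[C@H](Oc3cnc(S(C)(=O)=O)cn3)CC2)CC1` gives 356 nM. Compound 3 therefore stands second highest of the three numbers: its nearest neighbour is compound 1, whose higher number lies beyond the scatter, while compound 2 lies furthest from it, with a lower number also beyond the scatter. Compound 4 `CS(=O)(=O)c1cnc(O[C@H]2CC[C@H](OC3CCN(CC4(C(F)(F)F)CCCC4)CC3)CC2)cn1` has not yet been measured. It differs from compound 3 by a group of 10 heavy atoms (7 carbon, 3 fluorine; one five-membered non-aromatic ring of carbon only) in place of a group of 7 heavy atoms (4 carbon, 2 oxygen, 1 fluorine; no ring), on an amine nitrogen in a ring. For the measured compounds named here, no step between measured compounds bears on this change, so the expectation rests on compound 3 alone. The step expected is a 1.8-fold lower number from compound 3 to compound 4 (0.25 log units; within the scatter), a modest move towards a lower number. Compound 4 is estimated at 200 nM in this assay, with a range from 50 nM to 800 nM.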

Compound 4, half-maximal effective concentration: 101 nM
Beside the measured number, compound 4's estimate is 2.0-fold (0.30 log units) above it, and the stated range covers the measured number.
By their numbers in this assay, from the lowest: compounds 2 and 4 (each within the scatter of the next); then compound 3; then compound 1.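

In this assay, putting the group of 10 heavy atoms in place of the group of 7 heavy atoms on the amine nitrogen in a ring gives a 3.5-fold lower number from compound 3 to compound 4 (0.55 log units; beyond the scatter). This position therefore accepts a group with no hydrogen-bond acceptors and a five-membered non-aromatic ring of carbon only, and the number still falls. Nothing available here accounts for this step. As far as these compounds go, whether a six-membered ring of carbon only, or an amide on this nitrogen, would serve as well stays open. So does whether the same group would give a similar step on the core of compound 2.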